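Thioether replacing ether on the aryl ring of compound 2

The source may hold more compounds than are shown below. What is called first, only, known or untested is meant among the compounds shown, and "the series" means these compounds.

Two members of the series have been measured in a functional assay on 786-0 cells (Homo sapiens) for inhibition, read by sulforhodamine B assay, with a stated time of 48 h; on this read-out higher numbers stand for weaker inhibition of growth and lower numbers for stronger inhibition of growth. Compound 1 `CCOC(=O)C1=C(C)NC(=O)NC1c1ccc(O)c(O)c1` gives 25.7 ug/mL in this assay. Compound 2 `CCOC(=O)C1=C(C)NC(=S)NC1c1ccc(OC)cc1` carries a thione in the core in place of the carbonyl of compound 1 and a methoxy on the aryl ring. In this assay compound 2 gives 25.9 ug/mL. Of the two numbers shown, compound 2 stands level with compound 1: the two values lie within the scatter of each other, so nothing can be said of order or change between them.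

The step now followed goes from compound 2 to compound 3 `CCOC(=O)C1=C(C)NC(=S)NC1c1ccc(SC)cc1`, which is to be measured in this assay. The change is methylsulfanyl in place of methoxy on an aromatic carbon. For the measured compounds named here, no measured pair carries a comparable change, so no step size can be read from the data. The expected step from compound 2 to compound 3 is a 1.2-fold lower number from compound 2 to compound 3 (0.07 log units; within the scatter), which is estimated to stay within the scatter in either direction. Compound 3 is therefore expected to give about 22 ug/mL in this assay, with a range from 10 ug/mL to 50 ug/mL.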

Compound 3, concentration for 50% growth inhibition: 5.3 ug/mL
For compound 3 the middle estimate is 4.2-fold (0.62 log units) above the measured one, and the stated range ends above it.
By their numbers in this assay, from the lowest: compound 3; then compounds 1 and 2 (each within the scatter of the next).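

In this assay, for the compounds shown here, methylsulfanyl in place of methoxy on an aromatic carbon, para to a large group, gives a 4.9-fold lower number from compound 2 to compound 3 (0.69 log units; beyond the scatter); this is the only step that links two compounds differing in one place, and it shows that growth inhibition at this position responds to the exchange. The two groups match in heavy-atom count, in hydrogen-bond donors and acceptors, and in net charge, so those counts do not separate them, and the step goes with oxygen being replaced by sulfur in a group of otherwise the same shape of formula. No measurement of any property of these compounds bears on what lies behind this step.

From the compounds shown here alone, whether the step is particular to methylsulfanyl remains open: a longer chain on sulfur such as ethylsulfanyl, a chlorine or an amine on the same aromatic carbon could each test this. Going by these compounds, it is also open whether the same exchange gives a step of similar size with a carbonyl in place of the thione in the shared core.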